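The source may hold more compounds than are shown below. What is called first, only, known or untested is meant among the compounds shown, and "the series" means these compounds.

Compound 1 `Clc1ccc(Cc2nn3cc(-c4ccc(Br)cc4)nc3s2)cc1` in an ADME assay on CCRF-CEM cells (Homo sapiens) for cytotoxicity, with a stated time of 72 h (a lower number here means a stronger inhibitor, a higher number a weaker inhibitor), gives > 250000 nM, which is a limit of the assay rather than a number. Compound 2 `COc1ccc(-c2cn3nc(Cl)sc3n2)cc1` in this assay likewise gives > 250000 nM, again a limit. Compound 3 `Clc1ccc(Cc2nn3c(Br)c(-c4ccc(Br)cc4)nc3s2)cc1` in this assay gives 238000 nM.

Going by the values given here, compound 3 therefore stands as the only compound of the three with a number in this assay; the other two results are limits, and the limit of > 250000 nM in this assay, at which 2 of the 3 values shown sit, marks where they sit. Among the compounds with values here, the one measured step that can be judged, an at least 1.0-fold lower number from compound 1 to compound 3 (0.02 log units; that floor lies within the scatter), started from a limit and lands close to it, so it shows no movement that the scatter would not cover.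

Compound 4 `O=[N+]([O-])c1ccc(-c2nc3sc(Cc4ccc(Cl)cc4)nn3c2Br)cc1` arises from compound 3 by the change (nitro in place of bromo on an aromatic carbon). No measured step among these compounds exchanges a bromo for a nitro, so the step from compound 1 to compound 3 is the only guide, and it bears on the question merely by showing that compound 3 lies near the limit of this assay. On that footing no step beyond the scatter is expected in this assay, in either direction, and a result that is again a limit is the likely outcome.

Compound 4 is accordingly estimated at 250000 nM, with a range from 100000 nM to 600000 nM. The step this estimate implies, a 1.1-fold higher number from compound 3 to compound 4 (0.02 log units; within the scatter), is expected to stay within the scatter.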

Compound 4, half-maximal inhibitory concentration: 73000 nM
The estimate for compound 4 lay 3.4-fold (0.53 log units) above the measured number; the measured number lies below the stated range.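

In this assay the place on the six-membered aromatic ring of carbon only, para to a large group, turns out to respond to a change of substituent: nitro in place of bromo gives a 3.3-fold lower number from compound 3 to compound 4 (0.51 log units; beyond the scatter) as a modest step beyond the scatter. Going by these compounds alone, the earlier compounds offered no step that could be told from the scatter, so this is the first readable movement, and it shows that the number can leave the top of the range with the rest of the molecule unchanged, as compound 4 gives 73000 nM in this assay on the same core as compound 3. Compound 1 and compound 2 each rest on a limit and not on a number: the limit of > 250000 nM in this assay, at which 2 of the 4 values shown sit.

This reading rests on a single pair, so the compounds shown leave open whether the step belongs to nitro in particular or whether another group at this place, such as an amine, a nitrile or a carboxylic acid, would move the number as far, or further, or not at all. They also leave open whether the same exchange would give a step of like size with the other parts of the molecule changed, for instance with a longer chain in place of the chlorobenzyl side.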